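The source may report more compounds than this note shows. Statements on the series, on what has been measured and on what is new or still open speak of the compounds shown alone.

Of the compounds shown here, two from the same series have been measured in a functional assay on the whole organism for inhibition of sodium-dependent dopamine transporter (Mus musculus); on this read-out higher numbers stand for an effect only at larger amounts of compound and lower numbers for an effect already at smaller amounts. Compound 1, with the structure `CN1Cc2c(N)cccc2C(c2ccc(Cl)cc2)C1`, gives 1.5 mg/kg in this assay. Compound 2, with the structure `CCNC(=O)Nc1cccc2c1CN(C)CC2c1ccccc1`, is known only by a limit: in this assay compound 2 gives > 80 mg/kg, a boundary of the measurement rather than a number. This is the limit of > 80 mg/kg in this assay, at which 1 of the 2 values shown sits.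

Compound 3, with the structure `CCNCC(=O)Nc1cccc2c1CN(C)CC2c1ccccc1`, has not yet been measured. It differs from compound 2 in one place: (ethylamino)methyl in place of ethylamino on a carbonyl carbon. Among the compounds with values here, no step between two measured compounds is available to show what such a change does here, and compound 2 itself stands only at a limit, so the starting point is not a fixed number. The change from compound 2 to compound 3 is expected to make no difference beyond the scatter, which is what a number no higher from compound 2 to compound 3 (the limit leaves the size open) means. In this assay compound 3 is therefore expected to give about 80 mg/kg, with a likely range from 25 mg/kg to 250 mg/kg.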

Compound 3, dose for half-maximal effect: about 60 mg/kg
The estimate for compound 3 lay 1.3-fold (0.12 log units) above the measured number, and the stated range covers the measured number.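

Within the data shown here, with compound 3, this position carries a real number for the first time rather than a limit: in this assay compound 3 gives about 60 mg/kg. Placing (ethylamino)methyl in place of ethylamino on the carbonyl carbon gives an at least 1.3-fold lower number from compound 2 to compound 3 (0.12 log units; that floor lies within the scatter), and this figure is only a floor, so the true step could be larger or could be no real change at all. Compound 2 is known only by a limit, so the size of the step cannot be fixed: the limit of > 80 mg/kg in this assay, at which 1 of the 3 values shown sits.

The compounds shown leave open what a longer chain on the same carbonyl carbon, such as (propylamino)methyl, would give. They also leave open what a plain aminomethyl group or a carboxylic acid would give there.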